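This account rests on a few compounds, and the source may have more. Where it says the series, first, only, none or still open, it means among the compounds named here.

In a functional assay on K562 cells (Homo sapiens) for antiproliferative activity, read by MTT assay, with a stated time of 48 h (a lower number here means a stronger inhibitor, a higher number a weaker inhibitor), compound 3 `COC(=O)CNC(=O)c1ccc(Oc2nc3ccccc3nc2NC(C)(C)C)cc1` gives > 50000 nM, which is a limit of the assay and not a number. Compound 4 `C[C@H](NC(=O)c1ccc(Oc2nc3ccccc3nc2NC(C)(C)C)cc1)C(=O)O` has 1-carboxyethyl in place of (methoxycarbonyl)methyl on an amide-type nitrogen. For the measured compounds named here, no measured step covers this change. Going by the values given here, the one measured step, a 1.6-fold higher number from compound 1 to compound 2 (0.19 log units; within the scatter), lies elsewhere in the structure and gives no direct size. The closest guide is that compound 1 `Cc1nc2ccccc2nc1Oc1ccc(C(=O)N[C@@H](CC(C)C)C(=O)O)cc1`, which also carries a free carboxy group, gives 19500 nM, and compound 2 `CC[C@@H](C)[C@H](NC(=O)c1ccc(Oc2nc3ccccc3nc2C)cc1)C(=O)O`, likewise, gives 30500 nM. A modest move to a lower number in this assay is therefore expected, though a second limit is possible. The expected step is an at least 1.6-fold lower number from compound 3 to compound 4 (0.22 log units; that floor lies within the scatter). For compound 4 the estimate is 30000 nM, with an expected range of 12000 nM to 60000 nM.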

Compound 4, half-maximal inhibitory concentration: 26400 nM
Compound 4: the middle estimate sits 1.1-fold (0.06 log units) above what was measured; the range from low to high includes it.
By their numbers in this assay, from the lowest: compounds 1, 4 and 2 (each within the scatter of the next). At a limit, above all of these: compound 3.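

Putting 1-carboxyethyl in place of (methoxycarbonyl)methyl on an amide-type nitrogen gives, in this assay, an at least 1.8-fold lower number from compound 3 to compound 4 (0.27 log units; that floor lies within the scatter). This is the first step shown at this position, and it moves the shared core from a limit of the assay to a measured number. Its true size stays unknown because compound 3 is only a limit: the limit of > 50000 nM in this assay, at which 1 of the 4 values shown sits.

The compounds shown do not separate the free carboxylic acid from the added methyl branch and its defined stereocentre. On these data alone, how carboxymethyl, an amine or a longer chain on this nitrogen would read remains open.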